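Benzofuranyl for Ethynyl on a Nucleoside Core

This account rests on a few compounds, and the source may have more. Where it says the series, first, only, none or still open, it means among the compounds named here.

Going by the values given here, compound 1 `C#Cc1cn([C@@H]2O[C@H](CO)[C@@H](O)[C@H]2O)c2ncnc(OC)c12` is examined in a functional assay on HeLa S3 cells (Homo sapiens) for antiproliferative activity, read by XTT assay, with a stated time of 72 h (on this read-out higher numbers stand for weaker inhibition and lower numbers for stronger inhibition), where compound 1 gives 1730 nM, the only numeric value among the three compounds tested. Compound 2 `CNc1ncnc2c1c(-c1ccsc1)cn2[C@@H]1O[C@H](CO)[C@@H](O)[C@H]1O` reaches only the limit of the assay in this assay, giving > 20000 nM. Compound 3 `O=c1[nH]cnc2c1c(-c1cc3ccccc3o1)cn2[C@@H]1O[C@H](CO)[C@@H](O)[C@H]1O` likewise reaches only the limit of the assay in this assay, giving > 20000 nM. Among the compounds with values here, both compound 2 and compound 3 differ from compound 1 in more than one place, so no single step between measured compounds is available; what stands out is the limit of > 20000 nM in this assay, at which 2 of the 3 values shown sit.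

Compound 4 `COc1ncnc2c1c(-c1cc3ccccc3o1)cn2[C@@H]1O[C@H](CO)[C@@H](O)[C@H]1O` differs from compound 1 by 1-benzofuran-2-yl in place of ethynyl on an aromatic carbon. Within the data shown here, the change is large in size, and the one measured compound carrying the 1-benzofuran-2-yl group, compound 3, sits at the limit. A loss of potency beyond the usual scatter is therefore expected, though compound 3 also differs elsewhere from compound 1. Compound 4 is expected to give about 9000 nM, with a range from 2500 nM to 30000 nM. The expected step of a 5.2-fold higher number from compound 1 to compound 4 (0.72 log units; beyond the scatter) would be a weakening.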

Compound 4, half-maximal inhibitory concentration: 9240 nM
The estimate for compound 4 lay 1.0-fold (0.01 log units) below the measured number; the range from low to high includes it.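

In this assay, 1-benzofuran-2-yl in place of ethynyl gives a 5.3-fold higher number from compound 1 to compound 4 (0.73 log units; beyond the scatter), so this aromatic carbon accepts a group with two aromatic rings at a modest cost, and compound 4 still gives a measurable number. Compound 3, which also carries 1-benzofuran-2-yl, gives > 20000 nM, and this is a limit of the assay. Compound 4 thus shows that 1-benzofuran-2-yl at this carbon does not by itself bring a compound to the limit that marks much of this set: the limit of > 20000 nM in this assay, at which 2 of the 4 values shown sit.

The compounds shown leave open whether a smaller group at this carbon, such as phenyl or furan-2-yl, would give a number nearer that of compound 1. They also leave open how a primary amine in place of the methoxy group would behave with 1-benzofuran-2-yl kept.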